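The source may hold more compounds than are shown below. What is called first, only, known or untested is meant among the compounds shown, and "the series" means these compounds.

Three compounds have been measured in a functional assay on NCI-H460 cells (Homo sapiens) for inhibition, read by colorimetric assay and sulforhodamine B assay, with a stated time of 48 h; a lower number here means a stronger inhibitor of growth, a higher number a weaker inhibitor of growth:

Compound 1 `CCCCCCCCCCCC[C@@H](O)[C@H]1CC[C@H]([C@H](O)CCCCCCCCCCNC(=O)c2cncs2)O1` gives 34700 nM in this assay.
Compound 2 `CCCCCCCCCCCC[C@@H](O)[C@H]1CC[C@H]([C@H](O)CCCCCCCCCCNC(=O)c2ccnn2C)O1` gives 8130 nM in this assay.
Compound 3 `CCCCCCCCCCCC[C@@H](O)[C@H]1CC[C@H]([C@H](O)CCCCCCCCCCNC(=O)c2cccs2)O1` gives 2290 nM in this assay.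

Compound 1 stands at the highest number of the three, so it is the weakest growth inhibitor in this set: the nearest measured compound is compound 2, reached by a 4.3-fold lower number from compound 1 to compound 2 (0.63 log units; beyond the scatter), and the furthest is compound 3, reached by a 15-fold lower number from compound 1 to compound 3 (1.18 log units; beyond the scatter). Between the two lower compounds the gap is a 3.6-fold lower number from compound 2 to compound 3 (0.55 log units; beyond the scatter).

The unmeasured compound 4 `CCCCCCCCCCCC[C@@H](O)[C@H]1CC[C@H]([C@H](O)CCCCCCCCCCNC(=O)c2ccco2)O1` differs from compound 1 in one place: furan-2-yl in place of 1,3-thiazol-5-yl on a carbonyl carbon

The two measured steps from compound 1 both bear on this change, since each replaces the same 1,3-thiazol-5-yl on the carbonyl carbon by another five-membered aromatic ring. Both lowered the number beyond the scatter, the thiophen-2-yl compound more so than the 1-methyl-1H-pyrazol-5-yl compound. Furan-2-yl, like thiophen-2-yl, carries a single hetero atom, so compound 4 is expected to move in the same direction as compound 3, though whether it reaches as far is not settled by the three numbers shown. The expected step is an 8.7-fold lower number from compound 1 to compound 4 (0.94 log units; beyond the scatter). Compound 4 is therefore estimated at 4000 nM, within a range of 1200 nM to 13000 nM.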

Compound 4, concentration for 50% growth inhibition: 18200 nM
Compound 4: middle estimate off by 4.6-fold (0.66 log units), on the low side; the whole stated range lies below it.
By their numbers in this assay, from the lowest: compound 3; then compound 2; then compounds 4 and 1 (each within the scatter of the next).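

In this assay, the furan-2-yl amide stays close to the 1,3-thiazol-5-yl amide, at a 1.9-fold lower number from compound 1 to compound 4 (0.28 log units; within the scatter), so this change on the carbonyl carbon does not separate the two. Thiophen-2-yl and furan-2-yl, both five-membered aromatic rings with one hetero atom, behave differently here, at a 7.9-fold higher number from compound 3 to compound 4 (0.90 log units; beyond the scatter), so having one hetero atom in the ring does not by itself bring the low number of compound 3. The 1-methyl-1H-pyrazol-5-yl ring also keeps a small advantage, at a 2.2-fold higher number from compound 2 to compound 4 (0.35 log units; beyond the scatter), which leaves compound 3 clearly apart from the other three and makes its gain specific to thiophen-2-yl among these four rings.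

No measurement shown here accounts for the gap between the thiophen-2-yl and furan-2-yl amides. Going by these compounds, it remains open whether a phenyl ring or a thiophen-3-yl group on the same carbonyl carbon would give a number as low as that of compound 3, and whether the order of these rings would hold with a shorter chain leading to the amide nitrogen.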